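Working notes: methyl in place of chloro

The source may hold more compounds than are shown below. What is called first, only, known or untested is meant among the compounds shown, and "the series" means these compounds.

Measured so far:
- compound 1 `N#C/C(=C\c1ccccc1OS(=O)(=O)c1ccc([N+](=O)[O-])cc1)C(=O)Nc1nnc(Cc2ccc(Cl)cc2)s1` gives 66%
- compound 2 `N#C/C(=C\c1ccccc1OS(=O)(=O)c1ccc(F)cc1)C(=O)Nc1nnc(Cc2ccc(Cl)cc2)s1` gives 64%

Both values come from a functional assay on RS4-11 cells (Homo sapiens) for inhibition, read by CCK-8 assay, with a stated time of 48 h, tested at 20 uM (a lower number here means less inhibition of growth, a higher number more inhibition of growth at the concentration tested), and lie within the scatter of each other. Compound 2, at 64%, therefore stands level with compound 1. Compound 3 `Cc1ccc(Cc2nnc(NC(=O)/C(C#N)=C/c3ccccc3OS(=O)(=O)c3ccc(F)cc3)s2)cc1` differs from compound 2 as follows: methyl in place of chloro on an aromatic carbon. Within the data shown here, only one measured step exists, a number 2 percentage points lower from compound 1 to compound 2 (within the scatter), and it exchanges nitro for fluoro elsewhere in the molecule. Among the measured compounds shown here, no measured step alters the chloro group, so the data offer no direct guide to this change. For the measured compounds named here, the one available step stayed small, which gives weak support for expecting no shift beyond the scatter in this assay. The expected step is a number 3 percentage points lower from compound 2 to compound 3 (within the scatter). For compound 3 the estimated value is 61%, with an expected range from 46% to 73%.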

Compound 3, percent growth inhibition at one concentration: 73%
Estimate against measurement, compound 3: 12 percentage points below; measured number inside the range.
By their numbers in this assay, from the lowest: compounds 2, 1 and 3 (each within the scatter of the next).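

In this assay, among these compounds, 4-chlorobenzyl to 4-methylbenzyl gives a number 9 percentage points higher from compound 2 to compound 3 (within the scatter), the first reading at this position, since the earlier step changed a different place in the molecule. In this one pair, chloro is therefore not required to keep growth inhibition at the concentration tested, and methyl serves in its place with no step beyond the scatter. No measurement available here bears on the reason for this result.

The compounds shown leave open whether the same holds for other groups at this place on the ring, such as methoxy, an amine, a carboxylic acid or a longer chain. With a read-out at one concentration, they also leave open whether compound 2 and compound 3 would separate across a range of concentrations.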